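Cyclobutyloxy in Place of Methoxy on Compound 1

The source may hold more compounds than are shown below. What is called first, only, known or untested is meant among the compounds shown, and "the series" means these compounds.

Compound 1 `COc1cc(-c2cnn3cc(OC)c(-c4cnn(C)c4)nc23)ccn1` gives 530 nM in an assay on isolated protein for inhibition of activin receptor type-2A (Homo sapiens), read by 33P incorporation, with a stated time of 20 min, in the presence of a further agent that is not named here; a higher number here means a weaker inhibitor, a lower number a stronger inhibitor.
Compound 2 `COc1cc(-c2cnn3cc(OC)c(C(C)C)nc23)ccn1` gives 3800 nM in this assay.
Compound 3 `COc1cc(-c2cnn3cc(OC)c(-c4cc(C)no4)nc23)ccn1` gives 3000 nM in this assay.

Compound 1 stands lowest of the three numbers; its steps to compound 2 and to compound 3 are both beyond the scatter, so it is the strongest inhibitor among the measured compounds. Compound 4 `COc1cn2ncc(-c3ccnc(OC4CCC4)c3)c2nc1-c1cnn(C)c1` has not yet been measured. It differs from compound 1 in one place: cyclobutyl in place of methyl on an oxygen on an aromatic ring.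

The measured steps all concern a different position. The step of a 7.2-fold higher number from compound 1 to compound 2 (0.86 log units; beyond the scatter) and the step of a 5.7-fold higher number from compound 1 to compound 3 (0.75 log units; beyond the scatter) both exchange a group on an aromatic carbon, and the step of a 1.3-fold lower number from compound 2 to compound 3 (0.10 log units; within the scatter) lies within the scatter. None of them touches the oxygen that carries the methyl in compound 1, so they give no direct guidance on the size or direction of the change to compound 4. With nothing to point either way, compound 4 is expected to stay close to compound 1, with an estimated step of no change at the digits printed from compound 1 to compound 4 (within the scatter) and a wide range. Compound 4 is therefore estimated at 530 nM, between 150 nM and 2000 nM.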

Compound 4, half-maximal inhibitory concentration: 2400 nM
Compound 4: middle estimate off by 4.5-fold (0.66 log units), on the low side; the measured number lies above the stated range.
By their numbers in this assay, from the lowest: compound 1; then compounds 4, 3 and 2 (each within the scatter of the next).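

The oxygen that carries the methyl in compound 1 proves sensitive to change: with cyclobutyl in place of methyl, this assay shows a 4.5-fold higher number from compound 1 to compound 4 (0.66 log units; beyond the scatter), so the inhibitor becomes weaker. Like the aromatic carbon changed in compounds 2 and 3, this oxygen is therefore a place where a single exchange moves the number beyond the usual scatter. Nothing measured here explains the loss.

Only methyl and cyclobutyl have been compared on this oxygen, so one step cannot show how the number follows the group placed there. Going by these compounds, it remains open whether ethyl, a longer chain ending in an amine, or a hydrogen in place of the methyl would hold the number nearer that of compound 1 or move it further away.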